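Swapping one ring for another on the amide nitrogen

This account rests on a few compounds, and the source may have more. Where it says the series, first, only, none or still open, it means among the compounds named here.

Among the measured compounds shown here, the three compounds measured so far share one core and differ only in the group on the amide-type nitrogen. Compound 1 `CN(C)CCNC(=O)c1c(O)c2cccnc2n(-c2ccccc2)c1=O` carries a 2-(dimethylamino)ethyl there and gives 18.4% in a functional assay on the whole organism for inhibition, with Rattus norvegicus as the target, read by cytopathic effect and paw edema, at a dose of 100 mg/kg by the oral route; a lower number here means less inhibition, a higher number more inhibition at the dose given (going by the name of the read-out). Compound 2 `O=C(Nc1cccc([N+](=O)[O-])c1)c1c(O)c2cccnc2n(-c2ccccc2)c1=O` carries a 3-nitrophenyl and gives 7.4%. Compound 3 `Cc1ccccc1NC(=O)c1c(O)c2cccnc2n(-c2ccccc2)c1=O` carries a 2-methylphenyl and gives 9.8%. On these numbers compound 3 stands second highest of the three, but its distance to either neighbour is within the scatter: a number 2.4 percentage points higher from compound 2 to compound 3 (within the scatter) and a number 8.6 percentage points lower from compound 1 to compound 3 (within the scatter). For the measured compounds named here, only the step of a number 11 percentage points lower from compound 1 to compound 2 (beyond the scatter) lies beyond the scatter.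

Compound 4 `O=C(Nc1ccc(Cl)nc1)c1c(O)c2cccnc2n(-c2ccccc2)c1=O` is built from compound 3 by the change (6-chloropyridin-3-yl in place of 2-methylphenyl on an amide-type nitrogen). Going by the values given here, the one measured step that exchanges a ring on this nitrogen for another ring, a number 2.4 percentage points higher from compound 2 to compound 3 (within the scatter), stayed within the scatter, and both ring-bearing compounds sit low. Among the compounds with values here, nothing among the measured compounds speaks for a move beyond the scatter when one ring replaces another at this place. The step to compound 4 is therefore expected to be small, a number 0.8 percentage points lower from compound 3 to compound 4 (within the scatter), and of uncertain direction. Compound 4 is estimated at 9%, with a range from 1% to 19%.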

Compound 4, a percentage reported as inhibition, in the whole organism at one dose (the size of the read-out at that dose, not a potency): -4%
Beside the measured number, compound 4's estimate is 13 percentage points above it, and the stated range ends above it.
By their numbers in this assay, from the lowest: compound 4; then compounds 2, 3 and 1 (each within the scatter of the next, the first and the last beyond it).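

The earlier ring-for-ring step stayed within the scatter, but this exchange on the amide-type nitrogen does not: the number falls beyond it in both comparisons (a number 13.8 percentage points lower from compound 3 to compound 4 (beyond the scatter); a number 11.4 percentage points lower from compound 2 to compound 4 (beyond the scatter)). The identity of the ring at this place can therefore matter, even though the 3-nitrophenyl and 2-methylphenyl rings of compound 2 and compound 3 gave numbers within the scatter of each other. The 2-(dimethylamino)ethyl group of compound 1 now also stands clearly apart from a second ring-bearing compound (a number 22.4 percentage points lower from compound 1 to compound 4 (beyond the scatter)), although compound 3 still goes against any general rule that chain beats ring, and in this assay compound 4 gives a negative number (-4%), so it shows no inhibition at this dose.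

No measurement shown here explains why this ring differs from the other two. Since the 6-chloropyridin-3-yl ring brings a ring nitrogen and a chlorine together, the unchlorinated pyridin-3-yl ring and a plain phenyl ring would be needed to tell their shares apart, and a longer chain ending in a dimethylamine would test the other side of the series.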